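Swapping the aryl group on the sulfonyl: compound 3 to compound 4

The source may hold more compounds than are shown below. What is called first, only, known or untested is meant among the compounds shown, and "the series" means these compounds.

Measured compounds:
- compound 1, `COc1ccc(S(=O)(=O)c2cnc3ccc(C)cc3c2N2CCC(C)CC2)cc1Cl`, gives 93%
- compound 2, `Cc1ccc2ncc(S(=O)(=O)c3cc(Cl)cc(Cl)c3)c(N3CCC(C)CC3)c2c1`, gives 75%
- compound 3, `Cc1ccc2ncc(S(=O)(=O)c3cc(F)cc(F)c3)c(N3CCC(C)CC3)c2c1`, gives 72%

In an assay on isolated protein for displacement of a labelled ligand from metabotropic glutamate receptor 5 (Homo sapiens), with a stated time of 60 min, tested at 1 uM (a lower number here means less inhibition, a higher number more inhibition at the concentration tested (going by the name of the read-out)), compound 3 stands lowest of the three numbers, though its gap to compound 2 lies within the scatter; only compound 1 is clearly higher. Compound 4, `Cc1ccc2ncc(S(=O)(=O)c3ccc(Cl)cc3)c(N3CCC(C)CC3)c2c1`, differs from compound 3 by 4-chlorophenyl in place of 3,5-difluorophenyl on a sulfonyl sulfur. Two earlier steps bear on this. The step of a number 3 percentage points lower from compound 2 to compound 3 (within the scatter) shows that exchanging one halogen pattern for another on this ring barely moved the number. The steps of a number 18 percentage points lower from compound 1 to compound 2 (beyond the scatter) and a number 21 percentage points lower from compound 1 to compound 3 (beyond the scatter) show that a different substituent pattern on the same ring can shift it modestly. For the measured compounds named here, no measured compound carries a 4-chlorophenyl here, so the direction is uncertain; a small rise is expected, a number 6 percentage points higher from compound 3 to compound 4 (within the scatter), placing compound 4 at an estimated 78%, within 60% to 92%.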

Compound 4, a percentage reported as inhibition, at one concentration (the size of the read-out at that concentration, not a potency): 79%
The estimate for compound 4 lay 1 percentage points below the measured number; the measured number falls inside the stated range.
By their numbers in this assay, from the lowest: compounds 3, 2 and 4 (each within the scatter of the next); then compound 1.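

In this assay, the 4-chlorophenyl group on the sulfonyl sulfur, with one halogen, cannot be told apart from the two-halogen rings (a number 7 percentage points higher from compound 3 to compound 4 (within the scatter) and a number 4 percentage points higher from compound 2 to compound 4 (within the scatter)). The 3-chloro-4-methoxyphenyl group alone stays clear of the other three rings (a number 14 percentage points lower from compound 1 to compound 4 (beyond the scatter)). Nothing measured here explains these numbers.

The compounds shown leave open how 4-methoxyphenyl, with the methoxy group and no chlorine, would read. They also leave open what an amine or a carboxylic acid on this ring would do.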